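A few compounds are considered here, and "the series" means these few. Any claim that something is new, unique, unknown or untested is made for them only; others in the source may bear on it.

In a functional assay on MDA-MB-231 cells (Homo sapiens) for cytotoxicity, read by MTT assay, with a stated time of 68 h (on this read-out higher numbers stand for weaker inhibition and lower numbers for stronger inhibition), compound 1 `O=C(/C=C/c1cccc(OCc2ccccc2)c1)c1ccc([N+](=O)[O-])cc1` gives 23300 nM, compound 2 `O=C(/C=C/c1cccc(OCc2ccccc2)c1)c1ccc(O)cc1` gives 2900 nM, and compound 3 `Cc1ccc(C(=O)/C=C/c2cccc(OCc3ccccc3)c2)cc1` gives 15600 nM. Compound 3 therefore stands within the scatter of compound 1 and well above compound 2. Compound 4 `O=C(/C=C/c1cccc(OCc2ccccc2)c1)c1ccccc1` is still unmeasured. The change is hydrogen in place of methyl on an aromatic carbon. Within the data shown here, no measured step has hydrogen as one of its two ends. The closest evidence is a 1.5-fold lower number from compound 1 to compound 3 (0.17 log units; within the scatter), within the scatter, whereas an 8.0-fold lower number from compound 1 to compound 2 (0.90 log units; beyond the scatter) and a 5.4-fold higher number from compound 2 to compound 3 (0.73 log units; beyond the scatter) are modest steps that both involve the hydroxy group of compound 2. No change beyond the scatter is expected in this assay, and the estimated step is a 1.2-fold lower number from compound 3 to compound 4 (0.08 log units; within the scatter). For compound 4 the expected value is 13000 nM, with an estimated range of 5500 nM to 30000 nM.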

Compound 4, half-maximal inhibitory concentration: 20000 nM
For compound 4 the middle estimate is 1.5-fold (0.19 log units) below the measured one; the measured number falls inside the stated range.
By their numbers in this assay, from the lowest: compound 2; then compounds 3, 4 and 1 (each within the scatter of the next).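

In this assay, removing the methyl group leaves the number within the scatter, with a 1.3-fold higher number from compound 3 to compound 4 (0.11 log units; within the scatter) as the step, and removing the nitro group does the same, with a 1.2-fold lower number from compound 1 to compound 4 (0.07 log units; within the scatter) as the step. Hydrogen, methyl and nitro at this position therefore cannot be told apart, and only hydroxy stands apart, with a 6.9-fold higher number from compound 2 to compound 4 (0.84 log units; beyond the scatter) as the step, beyond the scatter. No measurement here bears on what lies behind this difference.
From the compounds shown here alone, whether an amine or a methoxy group at this position would match compound 2 or the other three remains open. So does whether the hydroxy step would carry over to another core.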